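This account rests on a few compounds, and the source may have more. Where it says the series, first, only, none or still open, it means among the compounds named here.

Measured so far:
- compound 1, `O=C(Nc1ccccc1)c1c(NO)cc(-c2ccc(F)cc2)oc1=O`, 10300 nM
- compound 2, `O=C(Nc1ccccc1)c1c(NO)cc(-c2ccc(Cl)cc2)oc1=O`, 11000 nM
- compound 3, `O=C(NCc1ccccc1)c1c(NO)cc(-c2ccc(F)cc2)oc1=O`, > 20000 nM

In an ADME assay on Huh-7 cells (Homo sapiens) for cytotoxicity, read by a luciferase reporter and WST assay, with a stated time of 3 days (a lower number here means that less compound is tolerated, a higher number that more compound is tolerated), compound 1 gives 10300 nM and compound 2 gives 11000 nM. Between them stands one change, (chloro in place of fluoro on an aromatic carbon), and the step of a 1.1-fold higher number from compound 1 to compound 2 (0.03 log units; within the scatter). For compound 3 the value > 20000 nM is a limit of this assay, not a number; this is the point described by the limit of > 20000 nM in this assay, at which 1 of the 3 values shown sits. Compound 3 differs from compound 1 by benzyl in place of phenyl on an amide-type nitrogen, with the step of an at least 1.9-fold higher number from compound 1 to compound 3 (0.28 log units; that floor lies within the scatter).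

Compound 4, `O=C(NCc1ccccc1)c1c(NO)cc(-c2ccc(Cl)cc2)oc1=O`, is not yet measured. It differs from compound 3 by chloro in place of fluoro on an aromatic carbon, the same change as from compound 1 to compound 2, at a place described in the same words. On compound 1 and compound 2 that change left the number within the scatter, so for compound 4 the expected step is a step that the limit leaves unreadable from compound 3 to compound 4, resting on a 1.1-fold higher number from compound 1 to compound 2 (0.03 log units; within the scatter) and on the limit that compound 3 reached. Compound 4 is estimated at 22000 nM in this assay, between 11000 nM and 45000 nM, with a fair chance that only a limit is reported again.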

Compound 4, half-maximal cytotoxic concentration: > 20000 nM
Compound 4 gave a limit, no number; the forecaster's own chance of this, stated with the estimate: 65%; the middle value is on the limit's open side.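

In this assay, benzyl in place of phenyl on an amide-type nitrogen now stands on the core of compound 2 as well as on the core of compound 1, and the new step reads an at least 1.8-fold higher number from compound 2 to compound 4 (0.25 log units; that floor lies within the scatter). Both steps are floors and not sizes, so this shows only that neither core gives a reading against the change, not that the change carries over with the same size: the same change on two cores in this assay, an at least 1.9-fold higher number (0.28 log units; that floor lies within the scatter) from compound 1 to compound 3 and an at least 1.8-fold higher number (0.25 log units; that floor lies within the scatter) from compound 2 to compound 4; the limit leaves it open whether they differ

Compound 3 and compound 4 are both limits of the assay, and the step between them, chloro in place of fluoro, cannot be read: the limit of > 20000 nM in this assay, at which 2 of the 4 values shown sit.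

Still open, going by these compounds, is what numbers compound 3 and compound 4 would give, and so whether the benzyl step goes beyond the scatter on either core. Also open, on these data alone, is how this assay responds to a longer chain than benzyl on the amide nitrogen, such as phenethyl, or to an amine or a carboxylic acid on the benzyl ring.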